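This account rests on a few compounds, and the source may have more. Where it says the series, first, only, none or still open, it means among the compounds named here.

In a functional assay on NCI-H460 cells (Homo sapiens) for inhibition, read by MTT assay, with a stated time of 24 h, tested at 1 ug/mL (on this read-out lower numbers stand for less inhibition of growth and higher numbers for more inhibition of growth at the one concentration tested), compound 1 `O=C(CCCCC(S)CCS)Nc1ccccc1` gives 4.3% and compound 2 `O=C(CCCCC(S)CCS)Nc1ccc(F)cc1` gives 6.84%, so the two stand level within the scatter. Compound 3 `COc1ccc(NC(=O)CCCCC(S)CCS)cc1` differs from compound 2 by methoxy in place of fluoro on an aromatic carbon, para to a large group. For the measured compounds named here, the one measured step bearing on this change is a number 2.5 percentage points higher from compound 1 to compound 2 (within the scatter), and it lies within the scatter. No step beyond the scatter is therefore expected in this assay, in either direction. The expected step is a number 0.8 percentage points lower from compound 2 to compound 3 (within the scatter). For compound 3 the estimated value is 6%, with an expected range of 0% to 15%.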

Compound 3, percent growth inhibition at one concentration: "not active" (no number reported)
For compound 3 the study gives words and no number; there is nothing to compare the estimate with.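

For the compounds shown here, compound 3 is reported only in words, so no step from compound 2 to compound 3 can be read, and no measurement at hand bears on this result. The compounds shown leave open whether methoxy in place of fluoro shifts growth inhibition at all.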